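Removing a chloro from the dichlorophenyl arm of a piperidinyl purine

This account rests on a few compounds, and the source may have more. Where it says the series, first, only, none or still open, it means among the compounds named here.

The account follows a single change from compound 2 to compound 4. Compound 2 is `Clc1ccc(-c2nc(N3CCCCC3)c3nc[nH]c3n2)cc1Cl`; in an assay on cells for displacement of a labelled ligand from adenosine receptor A1 (Homo sapiens), read by scintillation counting and radioligand binding, with a stated time of 60 min, tested at 10 uM (a higher number here means more inhibition at the concentration tested (going by the name of the read-out), a lower number less inhibition), compound 2 gives 24.1%, the lowest of the two plain numbers shown. Its nearest neighbour is compound 3, `CN1CCN(c2nc(-c3cccc(Cl)c3)nc3c2ncn3C)CC1`, which in this assay gives 45.7%, a gap beyond the scatter. Compound 1, `CN1CCN(c2nc(-c3ccc(Cl)c(Cl)c3)nc3[nH]cnc23)CC1`, is reported in this assay only as a limit, > 80%, and this is the limit (the limit of > 80% in this assay, at which 1 of the 3 values shown sits).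

Going by the values given here, the one measured step, a number at least 55.9 percentage points lower from compound 1 to compound 2 (beyond the scatter), is large but concerns a different place on the core. Compound 4 is `Clc1cccc(-c2nc(N3CCCCC3)c3nc[nH]c3n2)c1`, and its difference from compound 2 is hydrogen in place of chloro on an aromatic carbon. Among the compounds with values here, no measured step touches this position, so compound 4 is expected to change by a number 2.1 percentage points lower from compound 2 to compound 4 (within the scatter), a step that would lie within the scatter. The expected value for compound 4 in this assay is therefore 22%, with a likely range from 5% to 45%.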

Compound 4, a percentage reported as inhibition, at one concentration (the size of the read-out at that concentration, not a potency): > 80%
Compound 4: only a limit was reported; the forecaster's own chance of this, stated with the estimate: 5%; middle value at least 58 percentage points from the limit.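

In this assay, replacing the chloro with hydrogen on this aromatic carbon, ortho to a chloro group and para to a large group, gives a number at least 55.9 percentage points higher from compound 2 to compound 4 (beyond the scatter). The earlier compounds shown here showed a large step only at the piperidin-1-yl position; this one shows that, with piperidin-1-yl kept, the loss of a single chlorine atom from the aryl arm is enough to give a large rise in inhibition. The value of compound 4 is a limit and not a number, which leaves the full size of the step unknown, and it is one of two such values: the limit of > 80% in this assay, at which 2 of the 4 values shown sit.

The compounds shown leave open whether fluoro, methyl or methoxy at this position would behave like hydrogen or like chloro. They also leave open what removing the remaining chloro from compound 4 would do.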